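Dimethoxy exchange in a series held at the limit

The source may report more compounds than this note shows. Statements on the series, on what has been measured and on what is new or still open speak of the compounds shown alone.

In a functional assay on HGC-27 cells (Homo sapiens) for cytotoxicity, read by MTT assay, with a stated time of 48 h (a lower number here means a stronger inhibitor, a higher number a weaker inhibitor), compound 1 `COc1ccc(/C=C/C(=O)/C=C/c2cc3ccccc3nc2Oc2ccc(Br)cc2)c(OC)c1` gives > 10000 nM as a limit. Compound 2 `COc1ccc(OC)c(/C=C/C(=O)/C=C/c2cc3ccccc3nc2Oc2ccc(Br)cc2)c1` gives > 10000 nM as a limit. Compound 3 `COc1ccc(/C=C/C(=O)/C=C/c2cc3ccccc3nc2Oc2cccc(Cl)c2)c(OC)c1` gives > 10000 nM as a limit. Compound 3 therefore stands at the limit of > 10000 nM in this assay, at which 3 of the 3 values shown sit, and carries no number.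

Compound 4 `COc1ccc(OC)c(/C=C/C(=O)/C=C/c2cc3ccccc3nc2Oc2cccc(Cl)c2)c1` differs from compound 3 by 2,5-dimethoxyphenyl in place of 2,4-dimethoxyphenyl on a double-bonded chain carbon bound to a double-bonded chain carbon with 2,5-dimethoxyphenyl in place of 2,4-dimethoxyphenyl. The same exchange is a step that the two limits leave unreadable from compound 1 to compound 2 while 3-chlorophenyl in place of 4-bromophenyl is a step that the two limits leave unreadable from compound 1 to compound 3 and neither gives a size. No shift beyond the scatter is therefore expected in this assay and the expected change is a step that the limit leaves unreadable from compound 3 to compound 4 in no firm direction. Compound 4 is estimated at 15000 nM within a range of 6000 nM to 40000 nM if a number is reported at all.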

Compound 4, half-maximal inhibitory concentration: > 10000 nM
Compound 4 was reported as a limit; the forecaster's own chance of this, stated with the estimate: 85%; the middle value lies beyond the limit too.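

Compound 4 gives a limit, so the steps to it from compound 3 and compound 2 cannot be read in this assay: the limit of > 10000 nM in this assay, at which 4 of the 4 values shown sit.

From the compounds shown here alone, whether either exchange shifts activity at all, and in which direction, stays open.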